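Aryl chloro/methyl swap on the compound 3 scaffold

This account rests on a few compounds, and the source may have more. Where it says the series, first, only, none or still open, it means among the compounds named here.

Measured in a functional assay on HCT-116 cells (Homo sapiens) for antiproliferative activity, read by MTT assay, with a stated time of 72 h; on this read-out lower numbers stand for stronger inhibition of growth and higher numbers for weaker inhibition of growth:
- compound 1 `Cc1c(C(=O)Nc2ccc(SC#N)cc2)nnn1-c1ccc(C(C)C)cc1` gives 8400 nM
- compound 2 `Cc1ccc(-n2nnc(C(=O)Nc3ccc(SC#N)cc3)c2C)cc1C` gives > 100000 nM, which is a limit and not a number
- compound 3 `Cc1ccc(Cl)cc1-n1nnc(C(=O)Nc2ccc(SC#N)cc2)c1C` gives 8200 nM

Compound 3 at 8200 nM shares the low end of the values shown. Compound 4 `Cc1ccc(Cl)c(-n2nnc(C(=O)Nc3ccc(SC#N)cc3)c2C)c1` carries 2-chloro-5-methylphenyl in place of 5-chloro-2-methylphenyl on an aromatic nitrogen. The same atoms are joined differently.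

Changes to this group have given a 1.0-fold lower number from compound 1 to compound 3 (0.01 log units; within the scatter), within the scatter, but also the large steps of an at least 11-fold higher number from compound 1 to compound 2 (1.07 log units; beyond the scatter) and an at least 12-fold lower number from compound 2 to compound 3 (1.08 log units; beyond the scatter). For the measured compounds named here, no measured step makes this exact swap, so a modest rise with a wide, upward-leaning range is expected: a 1.7-fold higher number from compound 3 to compound 4 (0.23 log units; within the scatter). Compound 4 is estimated at 14000 nM, with an expected range of 4500 nM to 70000 nM.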

Compound 4, concentration for 50% growth inhibition: > 100000 nM
Compound 4: a limit, no number (the forecaster's own chance of this, stated with the estimate: 15%); middle value at least 7.1-fold (0.85 log units) from the limit.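

With the same atoms joined differently, 2-chloro-5-methylphenyl in place of 5-chloro-2-methylphenyl on the aromatic nitrogen gives an at least 12-fold higher number from compound 3 to compound 4 (1.08 log units; beyond the scatter) in this assay, showing that the arrangement of chlorine and methyl on this ring counts, not only their presence. Compound 4 gives > 100000 nM, a limit and not a number. The comparison with 4-isopropylphenyl shows an at least 11-fold higher number from compound 1 to compound 4 (1.07 log units; beyond the scatter), while the step between compound 2 and compound 4 cannot be read, with both at the limit: the limit of > 100000 nM in this assay, at which 2 of the 4 values shown sit.

From the compounds shown here alone, whether an amine or a carboxylic acid on this ring would keep the growth inhibition of compound 3 stays open. Where compound 2 and compound 4 lie beyond the limit also stays open.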